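Notes on the step from compound 3 to compound 4

The compounds below may be only part of what the source reports. "The series", "measured", "known", "first", "only" and "open" are said of these compounds alone.

Measured in an ADME assay on a cell-free system (plasma, Rattus norvegicus) for protein binding, read by LC-MS, using equilibrium dialysis, with a stated time of 6 h, tested at 1 uM
- compound 1 `CN1CC[C@@H](N(c2cc(C#CC(C)(C)C)sc2C(=O)O)C(=O)[C@H]2CC[C@H](C)CC2)C1=O` gives 99.8%
- compound 2 `CN1CC[C@H](N(c2cc(C#CC(C)(C)C)sc2C(=O)O)C(=O)[C@H]2CC[C@H](C)CC2)C1=O` gives 98.1%
- compound 3 `CN1CCC[C@H](N(c2cc(C#CC(C)(C)C)sc2C(=O)O)C(=O)[C@H]2CC[C@H](C)CC2)C1=O` gives 98.9%

Compound 3 stands clear of one neighbour but not the other, with a 5.5-fold higher unbound fraction from compound 1 to compound 3 (0.74 log units; beyond the scatter) and a 1.7-fold lower unbound fraction from compound 2 to compound 3 (0.24 log units; within the scatter) as its two gaps. Compound 4 `CN1CCCC[C@H](N(c2cc(C#CC(C)(C)C)sc2C(=O)O)C(=O)[C@H]2CC[C@H](C)CC2)C1=O` has 1-methyl-2-oxoazepan-3-yl in place of 1-methyl-2-oxopiperidin-3-yl on an amide-type nitrogen. The same kind of swap gave those two gaps, which run in opposite directions. Their disagreement traces to a 9.5-fold higher unbound fraction from compound 1 to compound 2 (0.98 log units; beyond the scatter), which goes with the fact that compounds 1 and 2 differ only in the configuration as drawn. No step beyond the scatter is therefore expected in this assay, and the expected change is a 1.2-fold lower unbound fraction from compound 3 to compound 4 (0.09 log units; within the scatter). For compound 4 the estimate is 99.1%, with an expected range of 97.8% to 99.7%.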

Compound 4, plasma protein binding: 99.2%
Compound 4: middle estimate off by 1.1-fold (0.05 log units) (unbound fraction), on the high side; low and high end bracket the measured number.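

In this assay, 1-methyl-2-oxoazepan-3-yl on the amide-type nitrogen reads the same as 1-methyl-2-oxopiperidin-3-yl within the scatter (a 1.4-fold lower unbound fraction from compound 3 to compound 4 (0.14 log units; within the scatter)). Against the two 1-methyl-2-oxopyrrolidin-3-yl compounds, the gaps lie beyond the scatter but run in opposite directions (a 2.4-fold lower unbound fraction from compound 2 to compound 4 (0.38 log units; beyond the scatter); a 4.0-fold higher unbound fraction from compound 1 to compound 4 (0.60 log units; beyond the scatter)). The direction therefore depends on which of those two compounds is the reference: the fact that compounds 1 and 2 differ only in the configuration as drawn.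

Still open, as far as these compounds go, is how the opposite configuration of the 1-methyl-2-oxoazepan-3-yl stereocentre would read. Also open, from the compounds shown here alone, is whether an open-chain amine on the amide-type nitrogen would leave the unbound fraction within the scatter.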